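The source may hold more compounds than are shown below. What is called first, only, known or untested is meant among the compounds shown, and "the series" means these compounds.

Measured so far in a functional assay on NCI-H1299 cells (Homo sapiens) for antiproliferative activity, read by resazurin assay, with a stated time of 72 h; on this read-out higher numbers stand for an effect only at larger amounts of compound and lower numbers for an effect already at smaller amounts:

- compound 1 `CC1=C(C(=O)c2ccc(F)c(F)c2)C(c2cccc(O)c2)NC(=S)N1C`: 1360 nM; 33000 nM; 783 nM (3 entries)
- compound 2 `CC1=C(C(=O)c2cccc(F)c2)C(c2cccc(O)c2)NC(=S)N1C`: 2770 nM
- compound 3 `CC1(C)CC(=O)C2=C(C1)NC(=S)NC2c1cccc(O)c1`: 881 nM

Only two of these compounds have a single number. Compound 2, at 2770 nM, holds the higher of the two, and compound 3, at 881 nM, lies lower by a gap beyond the usual scatter. Compound 1 has no single number, and the record shows (the several entries of compound 1 in this assay, 1360 nM; 33000 nM; 783 nM (3 entries)), a wide spread.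

The next compound to be tested is compound 4 `CC1=C(C(=O)c2ccc(F)cc2)C(c2cccc(O)c2)NC(=S)N1C`. It has the same atoms as compound 2, joined differently: 4-fluorophenyl in place of 3-fluorophenyl on a carbonyl carbon. In words, 4-fluorophenyl stands in place of 3-fluorophenyl on a carbonyl carbon.

Within the data shown here, no measured pair in this small set shows a change of this kind. In this assay, no step beyond the scatter is therefore expected, in either direction, and the expectation starts from compound 2 at 2770 nM. The estimated change is a 1.2-fold lower number from compound 2 to compound 4 (0.08 log units; within the scatter). The expected value for compound 4 is 2300 nM, with an estimated range from 800 nM to 7000 nM.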

Compound 4, half-maximal effective concentration: 2390 nM
The estimate for compound 4 lay 1.0-fold (0.02 log units) below the measured number; the measured number falls inside the stated range.
By their numbers in this assay, from the lowest: compound 3; then compounds 4 and 2 (each within the scatter of the next).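

In this assay, among these compounds, 4-fluorophenyl in place of 3-fluorophenyl on a carbonyl carbon gives a 1.2-fold lower number from compound 2 to compound 4 (0.06 log units; within the scatter), and this is the first measured pair in the set that differs in one place. On this one pair, the read-out does not separate the two fluorophenyl groups at this position, so moving the fluorine around that ring leaves the number within the usual scatter. Compound 1, which also carries fluorine on the ring at this carbonyl carbon, offers no single number to set beside compound 4, and its record is widely spread: the several entries of compound 1 in this assay, 1360 nM; 33000 nM; 783 nM (3 entries)

The compounds shown leave open whether this position tolerates groups other than fluorophenyl, such as 4-methoxyphenyl, 4-aminophenyl or a pyridyl ring. They also leave open whether the same exchange would stay within the scatter on a different core, such as that of compound 3.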